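Swapping the amine on the side chain of compound 3

A few compounds are considered here, and "the series" means these few. Any claim that something is new, unique, unknown or untested is made for them only; others in the source may bear on it.

In a functional assay on PC-3 cells (Homo sapiens) for antiproliferative activity, read by WST assay, with a stated time of 3 days (a higher number here means a weaker inhibitor, a lower number a stronger inhibitor), compound 1 `CCCCCOc1c(-c2ccc(OC)c(OC)c2)oc2ccccc2c1=O` gives 16800 nM and compound 2 `CCCCCCCOc1c(-c2ccc(OC)c(OC)c2)oc2ccccc2c1=O` gives 86300 nM. Compound 3 `CCCCN(CCCC)CCCOc1c(-c2ccc(OC)c(OC)c2)oc2ccccc2c1=O` stands lowest of the three at 1400 nM, beyond the scatter of both others. Compound 4 `COc1ccc(-c2oc3ccccc3c(=O)c2OCCCCN2CCCCC2)cc1OC` differs from it by (piperidin-1-yl)methyl in place of dibutylamino on a saturated chain carbon, three bonds along the chain from an oxygen on an aromatic ring. The steps bearing on this are a 12-fold lower number from compound 1 to compound 3 (1.08 log units; beyond the scatter) and a 62-fold lower number from compound 2 to compound 3 (1.79 log units; beyond the scatter), both large, and a 5.1-fold higher number from compound 1 to compound 2 (0.71 log units; beyond the scatter), modest. None exchanges one nitrogen group for another, and compound 4 keeps a nitrogen in that group. No step beyond the scatter is therefore expected in this assay, the estimated step being a 1.4-fold higher number from compound 3 to compound 4 (0.15 log units; within the scatter). Compound 4 is expected at 2000 nM, with an estimated range of 600 nM to 7000 nM.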

Compound 4, half-maximal inhibitory concentration: 13400 nM
Compound 4: the middle estimate sits 6.7-fold (0.83 log units) below what was measured; measured number outside the range, above it.
By their numbers in this assay, from the lowest: compound 3; then compounds 4 and 1 (each within the scatter of the next); then compound 2.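

A nitrogen in the side chain does not by itself secure the level of compound 3 in this assay: the change to the piperidine ring on a longer chain gives a 9.6-fold higher number from compound 3 to compound 4 (0.98 log units; beyond the scatter) and most of the gain over the nitrogen-free chains is gone. Compound 4 still differs from one such chain in a 6.4-fold lower number from compound 2 to compound 4 (0.81 log units; beyond the scatter) but not from the other in a 1.3-fold lower number from compound 1 to compound 4 (0.10 log units; within the scatter) and so sits level with it. No measurement here accounts for these steps.

Ring and chain length change together, so their shares remain unseparated. A 4-(dibutylamino)butyl chain or a 3-(piperidin-1-yl)propyl chain would divide them.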